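Swapping a Hydroxyphenyl Arm on a Shared Pyridine-Free Core

The source may hold more compounds than are shown below. What is called first, only, known or untested is meant among the compounds shown, and "the series" means these compounds.

Three compounds that share one core were tested in an assay on isolated protein for inhibition of DNA topoisomerase 1 (Homo sapiens), with a stated time of 30 min, tested at 100 uM; a higher number here means more inhibition at the concentration tested (going by the name of the read-out), a lower number less inhibition. Compound 1 `Oc1cccc(-c2cc(-c3cccc(O)c3)nc(-c3ccccc3O)c2)c1` gives 1.9% in this assay. Compound 2 `Oc1cccc(-c2cc(-c3cccc(O)c3)nc(-c3cccc(O)c3)c2)c1` gives 0%, and compound 3 `Oc1ccc(-c2cc(-c3cccc(O)c3)cc(-c3ccccc3O)n2)cc1` gives 8.4%. All three numbers lie within the scatter of one another, so compound 1 cannot be ranked against either neighbour: the step of a number 1.9 percentage points lower from compound 1 to compound 2 (within the scatter) and the step of a number 6.5 percentage points higher from compound 1 to compound 3 (within the scatter) are both within the scatter.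

Compound 4 `Oc1cccc(-c2cc(-c3ccccc3O)cc(-c3ccccc3O)n2)c1` has not yet been measured. It differs from compound 1 as follows: 2-hydroxyphenyl in place of 3-hydroxyphenyl on an aromatic carbon. The step from compound 1 to compound 2 is the same kind of swap run the other way, and it produced nothing beyond the scatter, so the reverse swap is expected to produce nothing beyond the scatter either. The expected step is therefore a number 1.1 percentage points higher from compound 1 to compound 4 (within the scatter). For compound 4 the estimated value in this assay is 3%, with a range from 0% to 12%.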

Compound 4, a percentage reported as inhibition, at one concentration (the size of the read-out at that concentration, not a potency): 0%
Estimate against measurement, compound 4: 3 percentage points above; the measured number falls inside the stated range.
By their numbers in this assay, from the lowest: compounds 2, 4, 1 and 3 (each within the scatter of the next).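

Going by these compounds alone, compound 4 is the first compound here with a 2-hydroxyphenyl group rather than a 3-hydroxyphenyl group on the carbon opposite the ring nitrogen. In this assay, this swap gives a number 1.9 percentage points lower from compound 1 to compound 4 (within the scatter), so moving the hydroxyl group around this one arm has no effect that can be told from the scatter. No measurement shown offers an explanation for this outcome.

The compounds shown leave open whether any other group at this position could give a number beyond the scatter, such as a 4-hydroxyphenyl group, which appears only elsewhere on the core, or a phenyl ring carrying an amine or a carboxylic acid in place of the hydroxyl. They also cannot say whether the same swap would behave alike with different arms on the rest of the shared core.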